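The source may report more compounds than this note shows. Statements on the series, on what has been measured and on what is new or still open speak of the compounds shown alone.

In a functional assay on A2780 cells (Homo sapiens) for cytotoxicity, read by MTT assay, with a stated time of 24 h (a higher number here means a weaker inhibitor, a lower number a stronger inhibitor), compound 1 `CCCCC[C@H](C[C@@H](O)C[C@H]1CC=CC(=O)O1)OC` gives 28900 nM and compound 2 `CCCCC[C@@H](C[C@@H](O)C[C@H]1CC=CC(=O)O1)OC` gives 33700 nM. Within the data shown here, compound 2 therefore stands level with compound 1, since a 1.2-fold higher number from compound 1 to compound 2 (0.07 log units; within the scatter) is the only measured step. The evidence on that step is the fact that compounds 1 and 2 differ only in the configuration as drawn.

Compound 3 `CCCCC[C@H](C[C@@H](O)C[C@@H]1CC=CC(=O)O1)OC` is related to compound 2 as follows: the two compounds have the same atoms and bonds and differ only in configuration as drawn: 2 of 3 stereo elements differ; a stereocentre at a saturated chain carbon is drawn S in compound 2 and R in compound 3; a stereocentre at a saturated ring carbon is drawn R in compound 2 and S in compound 3. The inversion at the saturated chain carbon has a measured counterpart in a 1.2-fold higher number from compound 1 to compound 2 (0.07 log units; within the scatter), so no shift beyond the scatter is expected from that stereocentre in this assay. Among the measured compounds shown here, the saturated ring carbon has the same drawn configuration in compounds 1 and 2, so no measured step bears on its inversion. On these data alone, this part of the change is untested, and the range is kept wide to allow for a shift in either direction.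

No direction is favoured, and the estimated 1.1-fold higher number from compound 2 to compound 3 (0.03 log units; within the scatter) is expected to remain within the scatter. For compound 3 the expected value is 36000 nM, with an estimated range of 14000 nM to 85000 nM.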

Compound 3, half-maximal inhibitory concentration: 54500 nM
Beside the measured number, compound 3's estimate is 1.5-fold (0.18 log units) below it, within the range that was stated.
By their numbers in this assay, from the lowest: compounds 1, 2 and 3 (each within the scatter of the next).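

In this assay, the saturated ring carbon now has a measured step of its own, and inverting it alone gives a 1.9-fold higher number from compound 1 to compound 3 (0.28 log units; within the scatter). This is the cleanest reading of that position, as the structures change at that stereocentre and nowhere else: the fact that compounds 1 and 3 differ only in the configuration as drawn. The inversion of both the saturated chain carbon and the saturated ring carbon gives a 1.6-fold higher number from compound 2 to compound 3 (0.21 log units; within the scatter), so neither the single inversion at the ring carbon nor this double inversion moves the number beyond the scatter, and the three compounds cannot be ranked in this assay.

On these data alone, the third stereo element is drawn alike in compound 1, compound 2 and compound 3, so what its inversion would do stays open, as does the configuration in which both it and the ring carbon are inverted. All three compounds also share the same atoms and bonds, so they say nothing on how the cytotoxic reading would respond to a longer chain or to an amine in place of the methoxy group.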